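The compounds below may be only part of what the source reports. "The series", "measured", "known", "first", "only" and "open" are said of these compounds alone.

Compound 1 `COc1ccc(Cn2ncc3c2NC(=O)CC(c2ccc(NC(=O)Nc4ccc(Cl)c(C(F)(F)F)c4)cc2)=N3)cc1` gives in a functional assay on A375P cells (Homo sapiens) for inhibition, read by MTT assay, with a stated time of 24 h (on this read-out lower numbers stand for stronger inhibition of growth and higher numbers for weaker inhibition of growth), a value of 3930 nM. Compound 2 `O=C1CC(c2ccc(NC(=O)Nc3ccc(Cl)c(C(F)(F)F)c3)cc2)=Nc2cn[nH]c2N1` reaches in this assay only the limit of > 30000 nM. The change between them, (hydrogen in place of 4-methoxybenzyl on an aromatic nitrogen), brings an at least 7.6-fold higher number from compound 1 to compound 2 (0.88 log units; beyond the scatter), a value that sits at the limit of > 30000 nM in this assay, at which 1 of the 3 values shown sits. Compound 3 `COc1ccc(Cn2ncc3c2NC(=O)CC(c2cccc(NC(=O)Nc4ccc(Cl)c(Cl)c4)c2)=N3)cc1` gives in this assay 3860 nM; the difference between its core and that of compound 1 is not broken down here. Compound 4 `O=C1CC(c2cccc(NC(=O)Nc3ccc(Cl)c(Cl)c3)c2)=Nc2cn[nH]c2N1` differs from compound 3 by hydrogen in place of 4-methoxybenzyl on an aromatic nitrogen, the same change as that from compound 1 to compound 2. Resting on the step from compound 1 to compound 2, an at least 7.6-fold higher number from compound 1 to compound 2 (0.88 log units; beyond the scatter), a step of similar size is expected here, namely a 6.5-fold higher number from compound 3 to compound 4 (0.81 log units; beyond the scatter). Compound 4 is therefore estimated to give about 25000 nM in this assay, expected between 10000 nM and 60000 nM.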

Compound 4, concentration for 50% growth inhibition: > 30000 nM
Compound 4 gave a limit, no number; the forecaster's own chance of this, stated with the estimate: 50%; middle value at least 1.2-fold (0.07 log units) away from the limit.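

Compound 4 gives > 30000 nM in this assay, which is a limit and not a number. Putting hydrogen in place of 4-methoxybenzyl on the aromatic nitrogen thus gives an at least 7.7-fold higher number from compound 3 to compound 4 (0.89 log units; beyond the scatter), so the direction seen on the core of compound 1 recurs on the core of compound 3. From the compounds shown here alone, the change carries over in direction across these two cores, but its size on each remains unknown: the same change on two cores in this assay, an at least 7.6-fold higher number (0.88 log units; beyond the scatter) from compound 1 to compound 2 and an at least 7.7-fold higher number (0.89 log units; beyond the scatter) from compound 3 to compound 4; the limit leaves it open whether they differ.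

The compounds shown leave open whether a smaller group on that nitrogen, such as methyl, would give values like those of compound 1 and compound 3. They also leave open whether plain benzyl, without the methoxy group, would do the same.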